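This account rests on a few compounds, and the source may have more. Where it says the series, first, only, none or still open, it means among the compounds named here.

Measured so far:
compound 1 `CCCc1cc(N)c2cc(NC(=O)/C=C/c3ccc(C(C)(C)C)cc3)ccc2n1` — 910 nM
compound 2 `CCCc1cc(N)c2cc(NC(=O)/C=C/c3ccc(F)cc3)ccc2n1` — 200 nM

For the measured compounds named here, in a functional assay on HEK293 cells for activation of melanin-concentrating hormone receptor 1 (Homo sapiens), read by inositol phosphate accumulation (on this read-out higher numbers stand for an effect only at larger amounts of compound and lower numbers for an effect already at smaller amounts), compound 2 gives 200 nM, the lowest of the two numbers at hand; compound 1 gives 910 nM, and the step of a 4.6-fold lower number from compound 1 to compound 2 (0.66 log units; beyond the scatter) is the only measured step. Compound 3 `CCCc1cc(N)c2cc(NC(=O)/C=C/c3ccc(C(C)C)cc3)ccc2n1` is not yet measured. It differs from compound 2 in one place: isopropyl in place of fluoro on an aromatic carbon. Going by the values given here, the one measured step that bears on this change is a 4.6-fold lower number from compound 1 to compound 2 (0.66 log units; beyond the scatter), in which fluoro replaced tert-butyl at the same place. Compound 3 goes back toward a carbon substituent, though to isopropyl rather than tert-butyl, so a rise of the number in this assay is expected, probably not beyond what the step from compound 1 to compound 2 showed. The expected step is a 2.5-fold higher number from compound 2 to compound 3 (0.40 log units; beyond the scatter). For compound 3 the estimate in this assay is 500 nM, with a range from 200 nM to 1300 nM.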

Compound 3, half-maximal effective concentration: 520 nM
Estimate against measurement, compound 3: 1.0-fold (0.02 log units) below; the measured number falls inside the stated range.
By their numbers in this assay, from the lowest: compound 2; then compounds 3 and 1 (each within the scatter of the next).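

At the aromatic carbon that carries fluoro in compound 2, this assay now gives a second comparison of fluoro with a carbon substituent: a 2.6-fold higher number from compound 2 to compound 3 (0.41 log units; beyond the scatter). The advantage of fluoro over tert-butyl therefore also holds against the smaller isopropyl, and it is no longer tied to a single group. Isopropyl and tert-butyl are not separated, with a 1.8-fold lower number from compound 1 to compound 3 (0.24 log units; within the scatter), so among these two branched carbon groups the read-out does not follow their size, and no measurement here explains why fluoro differs from either of them.

Still open, going by these compounds, is where hydrogen, chloro, methoxy or an amine at this place would fall relative to fluoro and the two branched groups. A straight propyl chain would show whether branching matters at all.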